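The compounds below may be only part of what the source reports. "The series", "measured", "known", "first", "only" and "open" are said of these compounds alone.

Compound 1 `CCN(CC)c1ccc2cc(C(=O)c3ccc(N4CCN(C(=O)CN5CCNCC5)CC4)cc3)oc2c1` is the parent of this small series, in which the piperazine amine nitrogen carries either hydrogen or a larger group. In an ADME assay on L02 cells (Homo sapiens) for cytotoxicity, read by MTT assay, with a stated time of 48 h (a higher number here means a weaker inhibitor, a lower number a stronger inhibitor), compound 1 gives > 100000 nM, which is a limit of the assay rather than a number. Compound 2 `CCN(CC)c1ccc2cc(C(=O)c3ccc(N4CCN(C(=O)CN5CCN(C(=O)/C=C/c6ccccc6)CC5)CC4)cc3)oc2c1` carries the (2-phenylethenyl)carbonyl group on that nitrogen. In this assay compound 2 also gives > 100000 nM, again a limit. The step that the two limits leave unreadable from compound 1 to compound 2 therefore cannot be read, because both ends sit at the limit of > 100000 nM in this assay, at which 2 of the 3 values shown sit. Among the compounds with values here, compound 3 `CCN(CC)c1ccc2cc(C(=O)c3ccc(N4CCN(C(=O)CN5CCN(S(=O)(=O)c6ccc(C(F)(F)F)cc6)CC5)CC4)cc3)oc2c1` carries a sulfonyl group bearing a trifluoromethylphenyl ring, and in this assay compound 3 gives 17000 nM, the only number among the three. Compound 4 `CCN(CC)c1ccc2cc(C(=O)c3ccc(N4CCN(C(=O)CN5CCN(S(=O)(=O)c6ccc(F)cc6)CC5)CC4)cc3)oc2c1` is the compound still to be measured; its change from compound 1 is (4-fluorophenyl)sulfonyl in place of hydrogen on an amine nitrogen in a ring. Within the data shown here, no measured step reports this exact change. What is known is that compound 1 stands only at a limit and compound 3, with a related sulfonyl group, gives a number. Compound 4 is therefore expected to fall near compound 3, with the step of an at least 3.3-fold lower number from compound 1 to compound 4 (0.52 log units; beyond the scatter) expected from the limit of compound 1. The estimate for compound 4 in this assay is 30000 nM, between 10000 nM and 100000 nM, with a real chance that only a limit is reported.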

Compound 4, half-maximal inhibitory concentration: 9240 nM
Beside the measured number, compound 4's estimate is 3.2-fold (0.51 log units) above it; the whole stated range lies above it.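

At the amine nitrogen in the ring, this assay now shows an at least 10-fold lower number from compound 1 to compound 4 (1.03 log units; beyond the scatter) and an at least 10-fold lower number from compound 2 to compound 4 (1.03 log units; beyond the scatter), so among the four compounds the two with an arylsulfonyl group, compound 3 and compound 4, give numbers, while the hydrogen of compound 1 and the (2-phenylethenyl)carbonyl group of compound 2 do not. Both of these steps start from a limit of the assay and not from a number: the limit of > 100000 nM in this assay, at which 2 of the 4 values shown sit. On the aromatic ring of the sulfonyl group, the change from trifluoromethyl to fluoro gives a 1.8-fold lower number from compound 3 to compound 4 (0.26 log units; within the scatter), which lies within the scatter, so in this assay this change does not separate the two sulfonyl compounds.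

The compounds shown do not tell whether the numbers go with the sulfonyl link or with the aromatic ring it carries, and a methylsulfonyl group on the same nitrogen would separate the two. On these data alone, it also remains open how a methoxy group or a plain hydrogen in place of the fluoro on that aromatic carbon would read in this assay.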